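Piperazine oxazole amides: stability with a chloro aryl

This account rests on a few compounds, and the source may have more. Where it says the series, first, only, none or still open, it means among the compounds named here.

Three members of the series have been run in an ADME assay (liver) for metabolic stability, with Liver microsome (Homo sapiens) as the target, read by LC-MS, using microsomes, with a stated time of 1 h, tested at 5 uM; a lower number here means that less of the compound is left, a higher number that more of the compound is left. Compound 1 `COc1cc(OC)cc(N2CCN(C(=O)c3oc(C)nc3-c3cccc(F)c3)CC2)c1` gives 11.3%, compound 2 `Cc1nc(-c2ccccc2)c(C(=O)N2CCN(c3cccc(C#N)c3)CC2)o1` gives 8% and compound 3 `Cc1nc(-c2cccc(F)c2)c(C(=O)N2CCN(c3cc(Cl)cc(Cl)c3)CC2)o1` gives 75.9%. Compound 2 stands at the low end of these numbers: its value sits within the scatter of compound 1, while the gap to compound 3 lies beyond the scatter.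

The next step is compound 4 `Cc1nc(-c2ccccc2)c(C(=O)N2CCN(c3cccc(Cl)c3)CC2)o1`, which differs from compound 2 by chloro in place of cyano on an aromatic carbon. For the measured compounds named here, the only measured step that touches the same part of the molecule is a number 64.6 percentage points higher from compound 1 to compound 3 (beyond the scatter), where chlorine entering the ring on the amine nitrogen went with a large rise. Going by the values given here, no measured pair shows the cyano group leaving, so the bearing of that step is indirect, and compound 4 carries a single chlorine where compound 3 carries two. A rise beyond the scatter is therefore expected, but of smaller size than that step. The estimate for compound 4 in this assay is 32%, within 12% to 60%, i.e. a step of a number 24 percentage points higher from compound 2 to compound 4 (beyond the scatter) is expected.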

Compound 4, percent of the compound remaining: 13.5%
Compound 4: the middle estimate sits 18.5 percentage points above what was measured, within the range that was stated.
By their numbers in this assay, from the lowest: compounds 2, 1 and 4 (each within the scatter of the next); then compound 3.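

In this assay the change from 3-cyanophenyl to 3-chlorophenyl gives a number 5.5 percentage points higher from compound 2 to compound 4 (within the scatter) and so does not separate chloro from cyano at this place on the ring. The large rise in a number 64.6 percentage points higher from compound 1 to compound 3 (beyond the scatter) therefore does not carry over to every change that brings chlorine onto this ring, and one chloro in place of cyano is not enough to produce such a rise here. No measurement on hand speaks to the cause of this result.

Compound 4 and compound 3 differ in more than one place, so the share of the second chlorine and of the fluorine on the other phenyl ring in the value of compound 3 stays unresolved. Also open, on these data alone, is how a trifluoromethyl group or a carboxylic acid in place of chloro on this aromatic carbon would read.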